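The source may hold more compounds than are shown below. What is called first, only, known or untested is meant among the compounds shown, and "the series" means these compounds.

Measured compounds and values in a functional assay on U2OS cells for antagonist activity at C-X-C chemokine receptor type 3 (Homo sapiens), read by beta-arrestin recruitment; on this read-out higher numbers stand for weaker inhibition and lower numbers for stronger inhibition:
compound 1 `CCCc1ncc(-c2nc(C(F)(F)F)sc2N2CCN(C(=O)Cn3cnc4cccnc43)[C@H](C)C2)cn1` gives 33 nM
compound 2 `Cc1nc(C)n(CC(=O)N2CCN(c3sc(C(F)(F)F)nc3-c3cnc(OC(C)C)nc3)C[C@H]2C)n1` gives 138 nM
compound 3 `CCCc1ncc(-c2nc(C(F)(F)F)sc2N2CCN(C(=O)Cn3nc(C)nc3C)[C@H](C)C2)cn1` gives 258 nM

Compound 3 holds the highest of the three numbers in this assay. Its gap to compound 2 is within the scatter; its gap to compound 1 is beyond it, and that gap arises at the amide-linked ring: a 7.8-fold higher number from compound 1 to compound 3 (0.89 log units; beyond the scatter). The other measured step keeps the amide side constant and alters the substituent on the six-membered ring: a 1.9-fold higher number from compound 2 to compound 3 (0.27 log units; within the scatter), a change that stays within the scatter.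

Compound 4 `CCOc1ccc(-c2nc(C(F)(F)F)sc2N2CCN(C(=O)Cn3nc(C)nc3C)[C@H](C)C2)cn1` is not yet measured. It differs from compound 3 at one aromatic carbon: 6-ethoxypyridin-3-yl in place of 2-propylpyrimidin-5-yl on an aromatic carbon. Going by the values given here, of the two measured steps, only the step from compound 2 to compound 3 touches the same six-membered ring, and it exchanged an alkoxy group for an alkyl group without moving the number beyond the scatter. The step from compound 1 to compound 3 concerns a different part of the molecule and gives no guidance here. The change to compound 4 again swaps alkyl for alkoxy on that ring and also alters the ring itself, so a somewhat larger movement than the measured step is possible but not indicated. For compound 4 the expected step in this assay is a 1.3-fold lower number from compound 3 to compound 4 (0.11 log units; within the scatter). Compound 4 is estimated at 200 nM, with a range from 60 nM to 700 nM.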

Compound 4, half-maximal inhibitory concentration: 505 nM
Estimate against measurement, compound 4: 2.5-fold (0.40 log units) below; the measured number falls inside the stated range.
By their numbers in this assay, from the lowest: compound 1; then compounds 2, 3 and 4 (each within the scatter of the next, the first and the last beyond it).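

In this assay, going by these compounds alone, with the amide side held constant, a 2.0-fold higher number from compound 3 to compound 4 (0.29 log units; within the scatter) leaves the exchange of 2-propylpyrimidin-5-yl for 6-ethoxypyridin-3-yl unresolved, while a 3.7-fold higher number from compound 2 to compound 4 (0.56 log units; beyond the scatter) is the first change at this aromatic carbon of the five-membered ring to go beyond the scatter. The position is therefore not indifferent to the group it carries, although the step is modest, and the separated pair both carry an alkoxy group, so the presence of an alkoxy group alone does not fix the number here. The compounds shown offer no measurement that accounts for this separation.

On these data alone, the step between compound 2 and compound 4 changes the ring and the alkoxy chain together, so the share of each remains open, as does whether the 6-ethoxypyridin-3-yl group would keep its standing with the amide-linked fused ring of compound 1 in place of the dimethyl triazole-type ring. As far as these compounds go, it also remains open how this position responds to an amine or a carboxylic acid on the six-membered ring, since every group seen here ends in an alkyl or alkoxy chain.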